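The compounds below may be only part of what the source reports. "The series", "measured", "known", "first", "only" and "open" are said of these compounds alone.

Measured in a functional assay on A-427 cells (Homo sapiens) for cytotoxicity, read by colorimetric assay and MTT assay (a higher number here means a weaker inhibitor, a lower number a stronger inhibitor), so far:

- compound 1 `COc1ccc2cc(-c3ccccc3)c(O)nc2c1` gives 10000 nM
- compound 2 `COc1cc(OC)c2cc(-c3ccc(OCc4ccccc4)cc3)c(O)nc2c1` gives 10000 nM
- compound 3 `COc1ccc(-c2cc3c(OC)cc(OC)cc3n(CC#N)c2=O)cc1` gives 10000 nM

Compound 3 at 10000 nM stands level with compound 1 and compound 2, so the numbers do not rank any of the three above another.

The next structure is compound 4 `COc1ccc(-c2cc3c(OC)cc(OC)cc3n(CC(=O)OCc3ccccc3)c2=O)cc1` and it changes compound 3 in one place. Benzyloxycarbonyl stands in place of cyano on a saturated chain carbon bound to an aromatic nitrogen benzyloxycarbonyl in place of cyano on a saturated chain carbon bound to an aromatic nitrogen and the same difference can be read as cyanomethyl to (benzyloxycarbonyl)methyl.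

Among the measured compounds shown here, no two measured compounds differ in only one place, so the data give no direct precedent for the size of this step. The best available guide is that the three structures differ from one another and still read alike, with compound 1 at 10000 nM and compound 2 at 10000 nM in this assay here. No step beyond the usual scatter is therefore expected, although a small move towards a stronger reading remains possible.

The estimated step of a 1.3-fold lower number from compound 3 to compound 4 (0.10 log units; within the scatter) is expected to be small.

For compound 4 the estimate is 8000 nM with an expected range from 2500 nM to 12000 nM in this measurement.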

Compound 4, half-maximal inhibitory concentration: 10000 nM
The estimate for compound 4 lay 1.3-fold (0.10 log units) below the measured number; the range from low to high includes it.
By their numbers in this assay, from the lowest: compounds 1, 2, 3 and 4 (each within the scatter of the next).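

In this assay, among the compounds shown here, benzyloxycarbonyl in place of cyano on a saturated chain carbon bound to an aromatic nitrogen gives no change at the digits printed from compound 3 to compound 4 (within the scatter), the first direct one-place comparison in this set. The swap is a large one on paper, with a cyano group of 2 heavy atoms giving way to a group of 10 heavy atoms that carries a six-membered aromatic ring of carbon only and 2 hydrogen-bond acceptors, yet compound 4 at 10000 nM reads level with compound 3 at 10000 nM, so at this position the size of the group made no difference that this read-out could show. No other measurement here bears on this result or accounts for it.

All four compounds share one printed number, so nothing shown yet identifies any change that moves the reading in either direction. As far as these compounds go, whether an amine or a carboxylic acid in place of cyano at this same place would read differently remains open, as does whether changes elsewhere on the shared core would matter more.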